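Longer chain in a series held at its limit

This account rests on a few compounds, and the source may have more. Where it says the series, first, only, none or still open, it means among the compounds named here.

Values in a functional assay on NCI-H460 cells (Homo sapiens) for antiproliferative activity, read by MTT assay, with a stated time of 48 h (a lower number here means a stronger inhibitor, a higher number a weaker inhibitor), each a limit and not a number:
- Compound 1 `CCCCCCC1(O)C(=O)Nc2ccc(Nc3ccc(OC)cc3)cc21` gives > 100000 nM
- Compound 2 `CCCCCC1(O)C(=O)Nc2ccc(Nc3ccc(C)cc3)cc21` gives > 100000 nM
- Compound 3 `CCCCCC1(O)C(=O)Nc2ccc(Nc3ccc(F)cc3)cc21` gives > 100000 nM

Compound 3 stands only at a limit, > 100000 nM, in this assay. Going by the values given here, the other two values are limits as well, so the whole series so far reads as the limit of > 100000 nM in this assay, at which 3 of the 3 values shown sit. Compound 4 `CCCCCCC1(O)C(=O)Nc2ccc(Nc3ccc(F)cc3)cc21` follows from compound 3 by a single change, (methyl in place of hydrogen on a saturated chain carbon, five bonds along the chain from a saturated ring carbon), with methyl in place of hydrogen on a saturated chain carbon, five bonds along the chain from a saturated ring carbon.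

Among the compounds with values here, the one measured step, a step that the two limits leave unreadable from compound 2 to compound 3, lies on an aromatic carbon and not on the chain, and it gives no size to carry over. The chain of compound 4 also stands in compound 1, which gives the limit > 100000 nM. No step beyond the scatter is expected in this assay, and the estimated a number no higher from compound 3 to compound 4 (the limit leaves the size open) has no favoured direction. For compound 4 the expected value is 100000 nM, with an estimated range from 30000 nM to 300000 nM, most likely reported again as a limit.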

Compound 4, half-maximal inhibitory concentration: 50700 nM
Estimate against measurement, compound 4: 2.0-fold (0.29 log units) above; the measured number falls inside the stated range.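

In this assay, compound 4 is the only compound shown that gives a number and not a limit, while the others stay at a limit: the limit of > 100000 nM in this assay, at which 3 of the 4 values shown sit.

Methyl in place of hydrogen on the saturated chain carbon gives an at least 1.9-fold lower number from compound 3 to compound 4 (0.29 log units; that floor lies within the scatter), and exchanging the methoxy group for a fluoro group, with the chain held, gives an at least 1.9-fold lower number from compound 1 to compound 4 (0.29 log units; that floor lies within the scatter). Both steps are floors only, so each change can bring the series off its limit, but neither has a size that can be read, and the step between compound 2 and compound 3 cannot be read at all.

As far as these compounds go, whether a longer chain than that of compound 4 gives a lower number remains open. So does whether a chloro or trifluoromethyl group in place of the fluoro of compound 4 keeps a number in this assay.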